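The source may hold more compounds than are shown below. What is called first, only, known or untested is meant among the compounds shown, and "the series" means these compounds.

Measured compounds:
compound 1 `Cc1ccccc1OS(=O)(=O)c1ccc(NC(=O)NCCCCl)cc1` — 26000 nM
compound 2 `Cc1ccccc1NS(=O)(=O)c1ccc(NC(=O)NCCCCl)cc1` — 64000 nM
compound 3 `CCCc1ccccc1NS(=O)(=O)c1ccc(NC(=O)NCCCCl)cc1` — 26000 nM

In a functional assay on HT-29 cells (Homo sapiens) for cytotoxicity, read by sulforhodamine B assay, with a stated time of 48 h (a lower number here means a stronger inhibitor, a higher number a weaker inhibitor), compound 2 gives the highest of the three numbers: the step of a 2.5-fold higher number from compound 1 to compound 2 (0.39 log units; beyond the scatter) raised it, and the step of a 2.5-fold lower number from compound 2 to compound 3 (0.39 log units; beyond the scatter) lowered it again. Compound 4 `CCNC(=O)Nc1ccc(S(=O)(=O)Nc2ccccc2C)cc1` is obtained from compound 2 by the change (hydrogen in place of chloromethyl on a saturated chain carbon, two bonds along the chain from an amide-type nitrogen); the same difference, cut one bond further out, reads 3-chloropropyl to ethyl. Both measured steps alter the part of the molecule around the sulfonyl sulfur, not the chain on the urea, so neither bears on this change, and the data give no guide to its size or direction. The expectation therefore stays close to compound 2, with a wide range, as a 1.6-fold higher number from compound 2 to compound 4 (0.19 log units; within the scatter). Compound 4 is estimated at 100000 nM, between 40000 nM and 250000 nM.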

Compound 4, half-maximal inhibitory concentration: > 200000 nM
Compound 4: a limit, no number (the forecaster's own chance of this, stated with the estimate: 30%); middle value at least 2.0-fold (0.30 log units) away from the limit.
By their numbers in this assay, from the lowest: compounds 1 and 3 (each within the scatter of the next); then compound 2. At a limit, above all of these: compound 4.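

Replacing 3-chloropropyl with ethyl is the first change shown on the urea chain rather than around the sulfonyl sulfur, and in this assay it gives a step beyond the scatter: an at least 3.1-fold higher number from compound 2 to compound 4 (0.49 log units; beyond the scatter). Compound 4 stands at a limit of the assay, not at a number: the limit of > 200000 nM in this assay, at which 1 of the 4 values shown sits. Going by these compounds, in this one pair, the chain carrying chlorine therefore gives the lower number, though by how much stays unknown.

On these data alone, whether the chlorine or the chain length matters remains open; a plain propyl chain would separate the two. Also open, as far as these compounds go, is whether the same change acts alike on compound 1 and compound 3.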